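Halogen swap from compound 3 to compound 4

The source may report more compounds than this note shows. Statements on the series, on what has been measured and on what is new or still open speak of the compounds shown alone.

Values in a functional assay on SGC-7901 cells (Homo sapiens) for antiproliferative activity, read by sulforhodamine B assay, with a stated time of 72 h; on this read-out higher numbers stand for weaker inhibition and lower numbers for stronger inhibition:
- compound 1 `S=C(NCc1ccccc1)N/N=C/c1ccc2ccccc2n1`: 53700 nM
- compound 2 `COc1cccc(NC(=S)N/N=C/c2ccc3ccccc3n2)c1`: 79400 nM
- compound 3 `S=C(N/N=C/c1ccc2ccccc2n1)Nc1ccc(Cl)cc1`: 87600 nM

The three values lie within the scatter of one another: a 1.6-fold higher number from compound 1 to compound 3 (0.21 log units; within the scatter) and a 1.1-fold higher number from compound 2 to compound 3 (0.04 log units; within the scatter). Compound 4 `S=C(N/N=C/c1ccc2ccccc2n1)Nc1ccc(Br)cc1` differs from compound 3 in one place: bromo in place of chloro on an aromatic carbon, para to a large group. Going by the values given here, no measured step exchanges one halogen for another. Among the compounds with values here, the only steps available change the group on the amide-type nitrogen, and these include a 1.5-fold higher number from compound 1 to compound 2 (0.17 log units; within the scatter), so no step beyond the scatter is expected in this assay. The expected step is a 1.3-fold lower number from compound 3 to compound 4 (0.10 log units; within the scatter). For compound 4 the estimated value is 70000 nM, with an expected range of 32000 nM to 130000 nM.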

Compound 4, half-maximal inhibitory concentration: 69400 nM
For compound 4 the middle estimate is 1.0-fold (0.00 log units) above the measured one; measured number inside the range.
By their numbers in this assay, from the lowest: compounds 1, 4, 2 and 3 (each within the scatter of the next).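

In this assay, the halogen on the aromatic carbon para to a large group can now be read directly: bromo in place of chloro gives a 1.3-fold lower number from compound 3 to compound 4 (0.10 log units; within the scatter). The 4-bromophenyl group also stays within the scatter of the other groups on the amide-type nitrogen, giving a 1.1-fold lower number from compound 2 to compound 4 (0.06 log units; within the scatter) and a 1.3-fold higher number from compound 1 to compound 4 (0.11 log units; within the scatter). No measured data bear on the reason for this clustering.

As far as these compounds go, whether an amine or a carboxylic acid at this position would give a step beyond the scatter remains open. So does the effect of changing the shared core.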